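The source may hold more compounds than are shown below. What is called first, only, known or untested is meant among the compounds shown, and "the series" means these compounds.

In a functional assay on MCF7 cells (Homo sapiens) for cytotoxicity, read by MTT assay, with a stated time of 48 h (on this read-out higher numbers stand for weaker inhibition and lower numbers for stronger inhibition), compound 2 `O=C1/C(=C\c2ccc(Cl)cc2)S/C(=N/c2ccccc2)N1Cc1ccncc1` gives 54900 nM. Compound 1 `COc1ccc(/C=C2/S/C(=N/c3ccccc3)N(Cc3ccncc3)C2=O)cc1` gives 31500 nM, and compound 3 `COc1ccc(OC)c(/C=C2/S/C(=N/c3ccccc3)N(Cc3ccncc3)C2=O)c1` gives 37000 nM. Compound 2 thus sits at the top of the three numbers, yet neither gap separates it from the others: a 1.7-fold higher number from compound 1 to compound 2 (0.24 log units; within the scatter), and a 1.5-fold lower number from compound 2 to compound 3 (0.17 log units; within the scatter). Compound 4 `O=C1/C(=C\c2ccccn2)S/C(=N/c2ccccc2)N1Cc1ccncc1` has not yet been measured. It differs from compound 2 in one place: pyridin-2-yl in place of 4-chlorophenyl on a double-bonded chain carbon bound to a double-bonded ring carbon. Among the measured compounds shown here, no measured step swaps a six-membered aromatic ring of carbon only for a six-membered aromatic ring with 1 hetero atom, so nothing bears on this change directly. The two steps that do exchange the group on the double-bonded chain carbon bound to a double-bonded ring carbon, a 1.7-fold higher number from compound 1 to compound 2 (0.24 log units; within the scatter) and a 1.5-fold lower number from compound 2 to compound 3 (0.17 log units; within the scatter), both stayed within the scatter, so the number for compound 4 is expected to stay close to that of compound 2, with a 1.2-fold lower number from compound 2 to compound 4 (0.09 log units; within the scatter) expected. Compound 4 is therefore estimated at 45000 nM, within a range of 15000 nM to 130000 nM.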

Compound 4, half-maximal inhibitory concentration: 21100 nM
Compound 4: middle estimate off by 2.1-fold (0.33 log units), on the high side; the measured number falls inside the stated range.
By their numbers in this assay, from the lowest: compounds 4, 1, 3 and 2 (each within the scatter of the next, the first and the last beyond it).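

In this assay, among the compounds shown here, a change on the double-bonded chain carbon bound to a double-bonded ring carbon now gives a step beyond the scatter for the first time (modest in size), as pyridin-2-yl replaces 4-chlorophenyl (a 2.6-fold lower number from compound 2 to compound 4 (0.42 log units; beyond the scatter)). The separation holds only against compound 2, since pyridin-2-yl stays within the scatter of both methoxy-bearing groups (a 1.8-fold lower number from compound 3 to compound 4 (0.24 log units; within the scatter) and a 1.5-fold lower number from compound 1 to compound 4 (0.17 log units; within the scatter)), so swapping a carbon-only aromatic ring for pyridin-2-yl brings no general shift across these compounds. Nothing measured here tells what lies behind the step from compound 2.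

Going by these compounds, it remains open whether a phenyl ring carrying a carboxylic acid or an amine at this place would read like compound 4 or like compound 2. On these data alone, whether an open chain such as butyl could stand in for the aromatic ring is equally open.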